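Two selenazole hydrazides and a phenyl for methyl swap

This account rests on a few compounds, and the source may have more. Where it says the series, first, only, none or still open, it means among the compounds named here.

Of the compounds shown here, two of this set have been tested in a functional assay on DU-145 cells (Homo sapiens) for cytotoxicity, read by XTT assay, with a stated time of 72 h; a higher number here means a weaker inhibitor, a lower number a stronger inhibitor. Compound 1, with the structure `ClCc1c[se]c(N/N=C/c2ccc(Cl)cc2)n1`, gives in this assay only a limit, > 75000 nM, and not a number. Compound 2, with the structure `CC(=O)N(C(=O)c1ccccc1)N(C(C)=O)c1nc(C)c[se]1`, likewise gives in this assay only a limit, > 68600 nM, which is not a number either. So compound 2 stands at the limit of the test rather than at a measured point, as stated by the limit of > 68600 nM in this assay, at which 1 of the 2 values shown sits, and compound 1 sits at the other limit described by the limit of > 75000 nM in this assay, at which 1 of the 2 values shown sits. The two cannot be placed in any order.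

Compound 3, with the structure `CC(=O)N(C(=O)c1ccccc1)N(C(C)=O)c1nc(-c2ccccc2)c[se]1`, has not yet been measured. It differs from compound 2 by phenyl in place of methyl on an aromatic carbon, in words a phenyl in place of methyl on an aromatic carbon. Among the measured compounds shown here, no measured pair of this kind exists here, so nothing shows how large such a change should be. With compound 2 already at a limit, the step that the limit leaves unreadable from compound 2 to compound 3 is expected to be none beyond the scatter. Compound 3 is therefore estimated at 70000 nM, within a range from 20000 nM to 200000 nM, and most likely the assay again reports only a limit.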

Compound 3, half-maximal inhibitory concentration: > 58600 nM
Compound 3: no number, only a limit; the forecaster's own chance of this, stated with the estimate: 75%; the middle value lies beyond the limit too.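

In this assay compound 3 gives only a limit, > 58600 nM, and not a number. Compound 2 also gives only a limit, > 68600 nM, and the step from compound 2 to compound 3 cannot be read. The compounds shown leave open whether phenyl in place of methyl on an aromatic carbon changes the result at all.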